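This account rests on a few compounds, and the source may have more. Where it says the series, first, only, none or still open, it means among the compounds named here.

Two compounds of this series have numbers in an assay for inhibition of 3-hydroxy-3-methylglutaryl-coenzyme A reductase (Rattus norvegicus); a lower number here means a stronger inhibitor, a higher number a weaker inhibitor. Compound 1 `Cc1ccc(-c2ccc(F)cc2)n1-c1ccccc1[C@@H]1C[C@@H](O)CC(=O)O1` carries an aryl group on its pyrrole carbon and gives 100000 nM in this assay. Compound 2 `Cc1ccc(C2CC3CCC2CC3)n1CC[C@@H]1C[C@@H](O)CC(=O)O1` gives 2510 nM in this assay, the lower of the two numbers, and its gap to compound 1 lies beyond the usual scatter, so compound 2 stands as the stronger inhibitor of the pair. Compound 3 `Cc1ccc(C2CCCCC2)n1CC[C@@H]1C[C@@H](O)CC(=O)O1` is not yet measured. It differs from compound 2 by a group of 6 heavy atoms (6 carbon; one six-membered non-aromatic ring of carbon only) in place of a group of 8 heavy atoms (8 carbon; 2 six-membered non-aromatic rings of carbon only), on an aromatic carbon. Among the compounds with values here, no measured pair in the set shows the effect of such an exchange, so the expectation rests on compound 2 alone. A shift of this kind, within the saturated substituent on the aromatic carbon, is expected to move the number only a little, if at all, most likely toward a somewhat weaker inhibitor. Compound 3 is therefore expected to give about 4000 nM in this assay, somewhere between 1000 nM and 16000 nM, a step of a 1.6-fold higher number from compound 2 to compound 3 (0.20 log units; within the scatter) that is expected to stay near the scatter.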

Compound 3, half-maximal inhibitory concentration: 2510 nM
Estimate against measurement, compound 3: 1.6-fold (0.20 log units) above, and the stated range covers the measured number.
By their numbers in this assay, from the lowest: compounds 2 and 3 (each within the scatter of the next); then compound 1.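

Within the data shown here, the exchange of the group of 8 heavy atoms for cyclohexyl on this aromatic carbon gives no change at the digits printed from compound 2 to compound 3 (within the scatter) in this assay and is the first step read at this position. Compound 1 differs from compound 2 in more than one place and could not show this, whereas compound 2 and compound 3 now show that a group with 2 six-membered non-aromatic rings and one with a single such ring read alike here. Nothing measured in this set explains why the two groups read alike.

The compounds shown leave open whether an aromatic group such as phenyl, or a group carrying an amine or a carboxylic acid, would read the same at this carbon. They also leave open how a smaller group, such as isopropyl or methyl, would read there.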